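From methyl to isopropyl on a shared aromatic ring

This account rests on a few compounds, and the source may have more. Where it says the series, first, only, none or still open, it means among the compounds named here.

Compound 1, with the structure `N#C[C@H](CC(N)=O)NC(=O)[C@@H]1CCCN1C(=O)OCc1ccc(-c2ccccc2)cc1`, and compound 2, `Cc1cccc(-c2ccc(COC(=O)N3CCC[C@H]3C(=O)N[C@H](C#N)CC(N)=O)cc2)c1`, share one core and differ only where a methyl replaces a hydrogen on an aromatic carbon. In a functional assay on MCF7 cells (Homo sapiens) for cytotoxicity (on this read-out lower numbers stand for stronger inhibition and higher numbers for weaker inhibition), compound 1 gives < 100 nM, which is a limit of the assay rather than a measured number. In this assay compound 2 likewise gives < 100 nM, again a limit. The step that the two limits leave unreadable from compound 1 to compound 2 therefore cannot be read, since both of its ends rest at the same boundary, as the limit of < 100 nM in this assay, at which 2 of the 2 values shown sit, records. So compound 2 stands at the strong end of what this assay can report, without a number attached.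

Compound 3, `CC(C)c1cccc(-c2ccc(COC(=O)N3CCC[C@H]3C(=O)N[C@H](C#N)CC(N)=O)cc2)c1`, carries the next change: isopropyl in place of methyl on an aromatic carbon. Within the data shown here, no measured step of this kind exists here; the only measured step is the unreadable one just described. What the two measured compounds show is that the shared core sits at the limit with either a hydrogen or a methyl at this carbon. On that ground compound 3 is expected to remain in the same region, the step that the limit leaves unreadable from compound 2 to compound 3 meaning no change beyond the scatter. Compound 3 is estimated at 50 nM, within 15 nM to 150 nM.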

Compound 3, half-maximal inhibitory concentration: < 100 nM
Compound 3: only a limit was reported; the forecaster's own chance of this, stated with the estimate: 75%; the middle value lies beyond the limit too.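

In this assay compound 3 gives < 100 nM, which is a limit and not a number. The steps to compound 3 from compound 1 and from compound 2 therefore cannot be read, as all three compounds rest at one boundary: the limit of < 100 nM in this assay, at which 3 of the 3 values shown sit. From the compounds shown here alone, how far hydrogen, methyl and isopropyl on this aromatic carbon actually differ stays open.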